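Swapping Cyano for Chloro on the Sulfonyl Phenyl

This account rests on a few compounds, and the source may have more. Where it says the series, first, only, none or still open, it means among the compounds named here.

Compound 3 `COc1ccc(-c2cc(=O)c3c(OC)cc(OC)cc3n2S(=O)(=O)c2ccc(C#N)cc2)cc1` carries a (4-cyanophenyl)sulfonyl group on the aromatic nitrogen of the shared core. In a functional assay on SUP-B15 cells (Homo sapiens) for antiproliferative activity, with a stated time of 72 h (a lower number here means that less compound is needed, a higher number that more compound is needed for the effect), compound 3 gives 7900 nM, the lowest of the two numbers recorded. Compound 1 `COc1ccc(-c2cc(=O)c3c(OC)cc(OC)cc3n2C)cc1` gives 28000 nM in this assay, and the step of a 3.5-fold lower number from compound 1 to compound 3 (0.55 log units; beyond the scatter) shows what the sulfonyl brings. Compound 2 `COc1ccc(-c2cc(=O)c3c(OC)cc(OC)cc3n2S(=O)(=O)c2cccc([N+](=O)[O-])c2)cc1` reaches only a limit of this assay, > 39600 nM. The step of an at least 5.0-fold lower number from compound 2 to compound 3 (0.70 log units; beyond the scatter) shows that the group on the sulfonyl phenyl matters. Compound 4 `COc1ccc(-c2cc(=O)c3c(OC)cc(OC)cc3n2S(=O)(=O)c2ccc(Cl)cc2)cc1` differs from compound 3 by chloro in place of cyano on an aromatic carbon. Neither measured step exchanges one small group for another on that phenyl ring, so no guide exists for direction. Compound 4 is therefore expected to give 7000 nM, between 2500 nM and 20000 nM, an estimated step of a 1.1-fold lower number from compound 3 to compound 4 (0.05 log units; within the scatter) within the scatter.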

Compound 4, half-maximal effective concentration: > 34400 nM
Compound 4: only a limit was reported; the forecaster's own chance of this, stated with the estimate: 10%; middle value at least 4.9-fold (0.69 log units) away from the limit.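

In this assay, chloro in place of cyano on the aromatic carbon gives an at least 4.3-fold higher number from compound 3 to compound 4 (0.63 log units; beyond the scatter), so even this small exchange on the sulfonyl phenyl ring changes the outcome. With chloro on that ring, the change from methyl gives an at least 1.2-fold higher number from compound 1 to compound 4 (0.08 log units; that floor lies within the scatter), so the sulfonyl group alone does not bring a lower number. Compound 4 gives only a limit: the limit of > 34400 nM in this assay, at which 1 of the 4 values shown sits.

The step between the two compounds known only by limits cannot be read. On these data alone, whether an amine or a carboxylic acid on this ring would match cyano remains open.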